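The source may report more compounds than this note shows. Statements on the series, on what has been measured and on what is new or still open speak of the compounds shown alone.

Measured in a functional assay on DU-145 cells (Homo sapiens) for cytotoxicity, read by sulforhodamine B assay, with a stated time of 48 h; on this read-out higher numbers stand for weaker inhibition and lower numbers for stronger inhibition:

- Compound 1 `C[C@H]1CC[C@@H]2[C@@H](OC(=O)[C@]23CC(c2ccc(N(C)C)cc2)=NO3)[C@]2(C)C(=O)C=C[C@@]12O`: 4500 nM
- Compound 2 `C[C@H]1CC[C@@H]2[C@@H](OC(=O)[C@]23CC(c2ccc(O)cc2)=NO3)[C@]2(C)C(=O)C=C[C@@]12O`: 93000 nM
- Compound 3 `C[C@H]1CC[C@@H]2[C@@H](OC(=O)[C@]23CC(c2ccccc2[N+](=O)[O-])=NO3)[C@]2(C)C(=O)C=C[C@@]12O`: 34000 nM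

Compound 3 holds the second highest of the three numbers, with a 2.7-fold lower number from compound 2 to compound 3 (0.44 log units; beyond the scatter) and a 7.6-fold higher number from compound 1 to compound 3 (0.88 log units; beyond the scatter). Compound 4 `C[C@H]1CC[C@@H]2[C@@H](OC(=O)[C@]23CC(c2cccc([N+](=O)[O-])c2)=NO3)[C@]2(C)C(=O)C=C[C@@]12O` differs from compound 3 by 3-nitrophenyl in place of 2-nitrophenyl on a carbon with a double bond to nitrogen. The nearest evidence is a 7.6-fold higher number from compound 1 to compound 3 (0.88 log units; beyond the scatter) and a 2.7-fold lower number from compound 2 to compound 3 (0.44 log units; beyond the scatter), modest steps that replace the whole group on that carbon. Among the compounds with values here, no measured pair keeps the nitro group and changes only its place, so little is expected from this change. The expected result in this assay is a 1.1-fold lower number from compound 3 to compound 4 (0.05 log units; within the scatter), with no shift beyond the scatter anticipated. Compound 4 is estimated at 30000 nM, with an expected range of 11000 nM to 80000 nM.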

Compound 4, half-maximal inhibitory concentration: 51000 nM
Compound 4: the middle estimate sits 1.7-fold (0.23 log units) below what was measured; low and high end bracket the measured number.
By their numbers in this assay, from the lowest: compound 1; then compounds 3, 4 and 2 (each within the scatter of the next, the first and the last beyond it).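

In this assay, 3-nitrophenyl in place of 2-nitrophenyl gives a 1.5-fold higher number from compound 3 to compound 4 (0.18 log units; within the scatter), so these two placings of the nitro group are not told apart. Against 4-hydroxyphenyl the step is a 1.8-fold lower number from compound 2 to compound 4 (0.26 log units; within the scatter), whereas against 4-(dimethylamino)phenyl it is an 11-fold higher number from compound 1 to compound 4 (1.05 log units; beyond the scatter), so of the groups shown on this carbon, only 4-(dimethylamino)phenyl stands apart from the others. Nothing measured here accounts for these numbers. As far as these compounds go, what 4-nitrophenyl gives on this carbon stays open, as does whether the result for 4-(dimethylamino)phenyl carries over to 4-aminophenyl or 4-methoxyphenyl.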